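Chloro in place of methoxy across two cores

The compounds below may be only part of what the source reports. "The series", "measured", "known", "first", "only" and "open" are said of these compounds alone.

Measured so far, in a functional assay (Cavia porcellus) with sulfonylurea receptors; K-ATP channels (Homo sapiens) as the target; on this read-out higher numbers stand for weaker inhibition and lower numbers for stronger inhibition:
compound 1 `COc1cccc(S(=O)(=O)c2ccc(NC(=O)C(C)(O)C(F)(F)F)cc2)c1` gives 16000 nM
compound 2 `CC(O)(C(=O)Nc1ccc(S(=O)(=O)c2cccc(Cl)c2)cc1)C(F)(F)F` gives 10000 nM
compound 3 `COc1cc(C(=O)c2ccccc2)ccc1NC(=O)C(C)(O)C(F)(F)F` gives 6100 nM

Compound 1 and compound 2 differ by chloro in place of methoxy on an aromatic carbon, and that change made a 1.6-fold lower number from compound 1 to compound 2 (0.20 log units; within the scatter). Compound 3 carries a different core; how its core differs from the core of compound 1 is not broken down here. Compound 4 `CC(O)(C(=O)Nc1ccc(C(=O)c2ccccc2)cc1Cl)C(F)(F)F` has not yet been measured in this assay. For the measured compounds named here, it differs from compound 3 by chloro in place of methoxy on an aromatic carbon, the same kind of change as the one from compound 1 to compound 2, but the place is not the same: here it is ortho to a large group and meta to a benzoyl group, whereas before it was meta to a large group. Resting on the earlier step of a 1.6-fold lower number from compound 1 to compound 2 (0.20 log units; within the scatter), the expected step is a 1.4-fold lower number from compound 3 to compound 4 (0.13 log units; within the scatter). Compound 4 is therefore estimated at 4500 nM, with a range from 1500 nM to 14000 nM.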

Compound 4, half-maximal inhibitory concentration: > 30000 nM
Compound 4 ended at the assay's limit (the forecaster's own chance of this, stated with the estimate: 5%); middle value at least 6.6-fold (0.82 log units) from the limit.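

Compound 4 reads > 30000 nM, which is a limit of the assay and not a number. Even so, in this assay chloro in place of methoxy gives an at least 4.9-fold higher number from compound 3 to compound 4 (0.69 log units; beyond the scatter), so the step seen on the core of compound 1 does not carry over to the core of compound 3: the same change on two cores in this assay, a 1.6-fold lower number (0.20 log units; within the scatter) from compound 1 to compound 2 and an at least 4.9-fold higher number (0.69 log units; beyond the scatter) from compound 3 to compound 4, at least 7.8-fold (0.89 log units) apart, beyond the scatter of two such steps
This rests on one pair per core, and the change sits in a different place on each core, so the effect of the core cannot be separated from that of the place, and neither the full size of the new step nor its cause is shown.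

Still open, on these data alone, is how the step would read with the change made elsewhere on the core of compound 3. Also open, as far as these compounds go, is how an amine or a nitrile in place of methoxy would read in this assay.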